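This account rests on a few compounds, and the source may have more. Where it says the series, first, only, none or still open, it means among the compounds named here.

Compound 1 `CC(Sc1ccc(Cl)cc1Cl)C(=O)NCc1ccc(F)cc1`: > 100000 nM
Compound 2 `CC(Cc1ccc(Cl)cc1Cl)C(=O)NCc1ccc(F)cc1`: "not determined" (no result reported)
Compound 3 `CC(Oc1ccc(Cl)cc1Cl)C(=O)NC(C)c1ccc(F)cc1`: > 100000 nM
Compound 4 `CC(Oc1ccc(Cl)cc1Cl)C(=O)N[C@@H](C)c1ccc(F)cc1`: not yet measured

In an ADME assay on CHO cells (Cricetulus griseus) for cytotoxicity, read by LDH release (on this read-out higher numbers stand for weaker inhibition and lower numbers for stronger inhibition), compound 3 gives > 100000 nM, which is a limit of the assay and not a number. This is the limit of > 100000 nM in this assay, at which 2 of the 3 values shown sit. Compound 4 differs from compound 3 only in how one stereocentre is drawn: the two compounds have the same atoms and bonds; at least one stereo element is drawn with a configuration in one of them and without one in the other: 1 of 2 stereo elements differ; a stereocentre at a saturated chain carbon is drawn without a configuration in compound 3 and S in compound 4. No measured step among these compounds shows what such a change does in this assay, so no shift beyond the usual scatter is expected. The estimated a number no higher from compound 3 to compound 4 (the limit leaves the size open) is accordingly small. For compound 4 the expected value is 100000 nM, with an estimated range from 50000 nM to 200000 nM, and a report of only a limit is likely.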

Compound 4, half-maximal inhibitory concentration: 32000 nM
Compound 4: the middle estimate sits 3.1-fold (0.49 log units) above what was measured; the whole stated range lies above it.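

In this assay, drawing this saturated chain carbon as S comes with an at least 3.1-fold lower number from compound 3 to compound 4 (0.49 log units; beyond the scatter), the only measured step among these compounds. As far as these compounds go, compound 3 gives > 100000 nM, which is a limit of the assay, so the true size of the step stays open. The read-out at this position can therefore differ beyond the usual scatter with no change in atoms or bonds, and the comparison rests on one structural difference: the fact that one of compounds 3 and 4 is drawn with a defined configuration and the other without, at the place where they differ

From the compounds shown here alone, how the R form would read remains open. So does the effect of an ethyl group in place of the methyl on this carbon.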